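Turning one stereocentre in a sulfonamide-bearing kinase inhibitor

This account rests on a few compounds, and the source may have more. Where it says the series, first, only, none or still open, it means among the compounds named here.

Measured so far in a functional assay on NCI-H1975 cells (Homo sapiens) for antiproliferative activity, read by MTT assay, with a stated time of 72 h; on this read-out higher numbers stand for weaker inhibition and lower numbers for stronger inhibition:
- compound 1, `CN1CCN(c2ccc(Nc3ncc4nc(Nc5ccccc5)n([C@H]5CCNC5)c4n3)cc2)CC1`: "not determined" (no result reported)
- compound 2, `CN1CCN(c2ccc(Nc3ncc4nc(Nc5ccc(F)cc5)n([C@@H]5CCN(S(=O)(=O)C6CC6)C5)c4n3)cc2)CC1`: > 10000 nM
- compound 3, `CN1CCN(c2ccc(Nc3ncc4nc(Nc5ccccc5)n([C@@H]5CCN(S(=O)(=O)C6CC6)C5)c4n3)cc2)CC1`: 200 nM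

Compound 2 gives only a limit of the assay in this assay, namely > 10000 nM, so no single number is known for it; this is the limit of > 10000 nM in this assay, at which 1 of the 3 values shown sits. For the measured compounds named here, compound 3, which carries hydrogen in place of fluoro on an aromatic carbon, is the one measured neighbour of compound 2, and that change produced an at least 50-fold lower number from compound 2 to compound 3 (1.69 log units; beyond the scatter). Compound 1 has no result in this assay.

Compound 4, `CN1CCN(c2ccc(Nc3ncc4nc(Nc5ccc(F)cc5)n([C@H]5CCN(S(=O)(=O)C6CC6)C5)c4n3)cc2)CC1`, differs from compound 2 as follows: the two compounds have the same atoms and bonds and differ only in configuration as drawn: 1 of 1 stereo elements differ; a stereocentre at a saturated ring carbon is drawn R in compound 2 and S in compound 4. Going by the values given here, none of the measured steps touches this stereocentre, so no measured step bears directly on the change, and the fluoro that accompanies the limit of compound 2 remains in place in compound 4. The expected outcome is therefore uncertain in both directions, and compound 4 is estimated at 8000 nM, with a range from 1000 nM to 40000 nM. This estimate corresponds to an expected step of an at least 1.2-fold lower number from compound 2 to compound 4 (0.09 log units; that floor lies within the scatter).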

Compound 4, half-maximal inhibitory concentration: 580 nM
Estimate against measurement, compound 4: 14-fold (1.14 log units) above; the whole stated range lies above it.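

The earlier compounds shown here tied a large step only to the fluoro, but compound 4 keeps that fluoro, and turning the stereocentre at a saturated ring carbon from R to S gives an at least 17-fold lower number from compound 2 to compound 4 (1.23 log units; beyond the scatter) in this assay. As far as these compounds go, compound 2 stands at > 10000 nM, which is a limit of the assay and not a number, so the full size of this step remains unknown. The step can be assigned to the stereocentre alone, because nothing else in the structure changes: the fact that compounds 2 and 4 differ only in the configuration as drawn

From the compounds shown here alone, it remains open whether turning this stereocentre would have a similar effect on compound 3, which has hydrogen in place of the fluoro. Also open, going by these compounds, is how each configuration would respond if the cyclopropyl on the sulfonamide were replaced by a methyl, or the sulfonamide by an amide.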